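Methyl for Methoxy on the Carbonyl-Bearing Aromatic Ring

This account rests on a few compounds, and the source may have more. Where it says the series, first, only, none or still open, it means among the compounds named here.

Two compounds share one core, measured in an assay on MDA-MB-231 cells for binding affinity to C-X-C chemokine receptor type 4 (Homo sapiens), read by immunofluorescence and microscopy, with stated times of 10 min and 30 min; a lower number here means that less compound is needed, a higher number that more compound is needed for the effect:
Compound 1: `O=C(NCc1ccc(CNS(=O)(=O)c2ccccc2)cc1)c1ccc(F)cc1` gives 100 nM
Compound 2: `COc1ccccc1C(=O)NCc1ccc(CNS(=O)(=O)c2ccccc2)cc1` gives 1 nM

Among the measured compounds shown here, compound 2 stands lowest of the two numbers; its nearest neighbour is compound 1, and the single measured step, a 100-fold lower number from compound 1 to compound 2 (2.00 log units; beyond the scatter), separates them, a change of 2-methoxyphenyl in place of 4-fluorophenyl on a carbonyl carbon. Compound 3, `Cc1ccccc1C(=O)NCc1ccc(CNS(=O)(=O)c2ccccc2)cc1`, keeps everything of compound 2 except that (methyl in place of methoxy on an aromatic carbon). For the measured compounds named here, the one measured step bears on compound 3 only loosely: it shows that the group on this aromatic ring matters greatly in this assay, but it sets a 2-methoxyphenyl against a 4-fluorophenyl, and no measured pair sets methoxy against methyl. Going by the values given here, the change therefore has no direct precedent here, and the large size of the one known step argues that even a small alteration of this ring can move the number far. The expectation for compound 3 is a moderate rise in number, a 5.0-fold higher number from compound 2 to compound 3 (0.70 log units; beyond the scatter), with wide uncertainty. Compound 3 is estimated at 5 nM, in the range 1 nM to 40 nM.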

Compound 3, effective concentration (reported as EC, without a stated level of effect): 1 nM
Beside the measured number, compound 3's estimate is 5.0-fold (0.70 log units) above it; measured number inside the range.
By their numbers in this assay, from the lowest: compounds 2 and 3 (each within the scatter of the next); then compound 1.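

In this assay, methyl in place of methoxy on this aromatic carbon gives no change at the digits printed from compound 2 to compound 3 (within the scatter), so this position accepts the 2-methylphenyl group as well as the 2-methoxyphenyl group, even though methyl carries no hydrogen-bond acceptor and methoxy carries one. The step with 2-methylphenyl in place of 4-fluorophenyl, a 100-fold lower number from compound 1 to compound 3 (2.00 log units; beyond the scatter), matches the earlier one with 2-methoxyphenyl in place of 4-fluorophenyl, a 100-fold lower number from compound 1 to compound 2 (2.00 log units; beyond the scatter), so the large drop in number does not depend on the oxygen of the methoxy group. Nothing available here explains why the methoxy and methyl compounds read alike.

The compounds shown leave open whether the drop comes from the group on this carbon or from the loss of fluorine at its own place on the ring, a question that a plain phenyl ring or a 2-fluorophenyl ring would address. They also do not show how far this position tolerates other groups, such as an ethyl group, an amine or a carboxylic acid, or whether the low number would hold with any of them in place of methyl.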